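Spirocyclic diamine in place of fused bicyclic amine

The compounds below may be only part of what the source reports. "The series", "measured", "known", "first", "only" and "open" are said of these compounds alone.

Working notes on the series. Compound 1 `O=C(Nc1ccnnc1)c1cc(N2C[C@H]3COC[C@H]3C2)ccc1OCc1ccccc1` gives 50.1 nM in an assay on Sf9 cells for inhibition of Leucine-rich repeat serine/threonine-protein kinase 2 (Homo sapiens), read by TR-FRET, with stated times of 30 min and 2 h (on this read-out lower numbers stand for stronger inhibition and higher numbers for weaker inhibition), the highest of the three numbers recorded so far. Compound 2 `O=C(Nc1cccnc1)c1cc(C(F)(F)F)ccc1OCc1ccccc1` gives 12.6 nM in this assay, and compound 3 `N#Cc1cccc(NC(=O)c2cc(C(F)(F)F)ccc2OCc2ccc(F)cc2)c1` gives 7.94 nM, both lower than compound 1 by margins beyond the scatter. Compound 4 `CN1CC2(C1)CN(c1ccc(OCc3ccccc3)c(C(=O)Nc3ccnnc3)c1)C2` is not yet measured. Relative to compound 1 it differs in one place: a group of 8 heavy atoms (6 carbon, 2 nitrogen; 2 four-membered non-aromatic rings with 1 hetero atom each) in place of a group of 8 heavy atoms (6 carbon, 1 nitrogen, 1 oxygen; 2 five-membered non-aromatic rings with 1 hetero atom each), on an aromatic carbon. Within the data shown here, no step between measured compounds speaks to this change, so the expectation rests on compound 1 and the size of its number. The expected step of a 1.3-fold higher number from compound 1 to compound 4 (0.10 log units; within the scatter) is small, toward a slightly higher number, within the scatter. Compound 4 is estimated at 63 nM, with a range of 20 nM to 200 nM.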

Compound 4, half-maximal inhibitory concentration: 25.1 nM
Beside the measured number, compound 4's estimate is 2.5-fold (0.40 log units) above it; measured number inside the range.
By their numbers in this assay, from the lowest: compounds 3, 2, 4 and 1 (each within the scatter of the next, the first and the last beyond it).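

In this assay, the step of a 2.0-fold lower number from compound 1 to compound 4 (0.30 log units; within the scatter) is the only one read at this position, on the aromatic carbon para to a benzyloxy group: exchanging the two five-membered rings for the two four-membered rings, with nitrogen in place of oxygen, causes no shift beyond the scatter. The entering group has no defined stereocentres, so those of the leaving group are not required for a number in this range. No measurement here explains this result.

Ring size and the exchange of oxygen for nitrogen change together, so neither can be read alone. A single-ring amine such as morpholine or piperazine at this position remains an open comparison.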